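Compound 3 to compound 4: losing the side-chain amino group

The source may report more compounds than this note shows. Statements on the series, on what has been measured and on what is new or still open speak of the compounds shown alone.

In an ADME assay on L02 cells (Homo sapiens) for cytotoxicity, read by MTT assay, with a stated time of 48 h (on this read-out higher numbers stand for weaker inhibition and lower numbers for stronger inhibition), compound 3 `CCn1c(C(=O)NCCN)ccc1C(CC)(CC)c1ccc(OCC(O)C(C)(C)C)c(C)c1` gives 2400 nM. Compound 1 `CCN(CC)CCCNC(=O)c1ccc(C(CC)(CC)c2ccc(OCC(O)C(C)(C)C)c(C)c2)n1CC` gives 2500 nM, and the two cannot be told apart, with a 1.0-fold lower number from compound 1 to compound 3 (0.02 log units; within the scatter). Compound 2 `CCn1c(C(=O)NCC(OC)OC)ccc1C(CC)(CC)c1ccc(OCC(O)C(C)(C)C)c(C)c1` gives 22200 nM, and a 9.3-fold lower number from compound 2 to compound 3 (0.97 log units; beyond the scatter) sets compound 3 clearly apart from it.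

Compound 4 `C#CC(C)OC(=O)c1ccc(C(CC)(CC)c2ccc(OCC(O)C(C)(C)C)c(C)c2)n1CC` has (1-methylprop-2-yn-1-yl)oxy in place of (2-aminoethyl)amino on a carbonyl carbon. Among the measured compounds shown here, no measured step makes this exchange, since all three measured compounds keep the amide-type nitrogen, so the evidence is indirect. The closest guide is compound 2, which, like compound 4, has no amino group on its side chain. Among these three compounds, the one lacking that group stands apart, with an 8.9-fold higher number from compound 1 to compound 2 (0.95 log units; beyond the scatter) and a 9.3-fold lower number from compound 2 to compound 3 (0.97 log units; beyond the scatter). For the measured compounds named here, no measured compound goes against this, though three compounds make a thin basis.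

A move to a higher number is therefore expected in this assay, somewhat smaller than those steps, and the estimated change is a 5.8-fold higher number from compound 3 to compound 4 (0.77 log units; beyond the scatter). Compound 4 is estimated at 14000 nM, with an expected range of 5000 nM to 40000 nM.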

Compound 4, half-maximal inhibitory concentration: 23700 nM
For compound 4 the middle estimate is 1.7-fold (0.23 log units) below the measured one, within the range that was stated.
By their numbers in this assay, from the lowest: compounds 3 and 1 (each within the scatter of the next); then compounds 2 and 4 (each within the scatter of the next).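

In this assay, (1-methylprop-2-yn-1-yl)oxy on the carbonyl carbon gives a clear move away from (2-aminoethyl)amino (a 9.9-fold higher number from compound 3 to compound 4 (0.99 log units; beyond the scatter)) and a move of similar size away from (3-(diethylamino)propyl)amino (a 9.5-fold higher number from compound 1 to compound 4 (0.98 log units; beyond the scatter)). Against (2,2-dimethoxyethyl)amino, the same group makes no difference that can be told apart from the scatter (a 1.1-fold higher number from compound 2 to compound 4 (0.03 log units; within the scatter)), which shows that this position tolerates the loss of the amide-type nitrogen without any further shift once the side-chain amine is already gone. The four compounds now fall into two pairs, with the amine-bearing compound 1 and compound 3 on one side and the amine-free compound 2 and compound 4 on the other, and none goes against this split, although nothing shown explains it.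

It remains open whether the amine alone sets this split, since the amine-free side chains shown differ widely from one another. A primary amine attached through oxygen rather than through the amide-type nitrogen, a carboxylic acid on the carbonyl carbon, or a saturated butyl ester in place of the alkyne-bearing chain would each test a separate part of that question.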